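Swapping Furan for Thiophene on the Carbonyl

The source may hold more compounds than are shown below. What is called first, only, known or untested is meant among the compounds shown, and "the series" means these compounds.

Of the compounds shown here, two built on one shared core have been tested in a functional assay on HepG2 cells (Homo sapiens) for cytotoxicity, read by MTT assay, with a stated time of 48 h; on this read-out lower numbers stand for stronger inhibition and higher numbers for weaker inhibition. Compound 1, `COc1cc(-c2nnc3n2NC(c2cccs2)C(C(=O)c2ccc(C)cc2)S3)cc(OC)c1OC`, carries a thiophene on the amine-bearing ring carbon and a methyl-substituted phenyl on the carbonyl; in this assay compound 1 gives 3700 nM. Compound 2, `COc1cc(-c2nnc3n2NC(c2ccco2)C(C(=O)c2ccco2)S3)cc(OC)c1OC`, carries a furan in both of those places. In this assay compound 2 reaches only a limit of the assay, > 100000 nM, so no number is known for it. That limit is the limit of > 100000 nM in this assay, at which 1 of the 2 values shown sits, and it is where compound 2 stands. The two compounds differ in two places at once, so the values simply show that compound 1 yields a number while compound 2 does not.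

Compound 3, `COc1cc(-c2nnc3n2NC(c2ccco2)C(C(=O)c2cccs2)S3)cc(OC)c1OC`, is the next step from compound 2, and the change is thiophen-2-yl in place of furan-2-yl on a carbonyl carbon. With compound 2 sitting only at a limit, the step from compound 2 to compound 3 is expected to be an at least 2.0-fold lower number from compound 2 to compound 3 (0.30 log units; that floor lies within the scatter), a gain into measurable territory but modest. Compound 3 is therefore estimated at 50000 nM, somewhere between 10000 nM and 200000 nM.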

Compound 3, half-maximal inhibitory concentration: 64100 nM
Compound 3: the middle estimate sits 1.3-fold (0.11 log units) below what was measured; measured number inside the range.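

In this assay compound 2 gives > 100000 nM, which is a limit of the assay and not a number. The earlier pair differed in two places at once, whereas here a single group changes on a carbonyl carbon, and thiophen-2-yl in place of furan-2-yl gives an at least 1.5-fold lower number from compound 2 to compound 3 (0.19 log units; that floor lies within the scatter), so this one swap is enough to bring a number within reach of the assay, though the smallest step it allows is no larger than the ordinary spread of repeated measurements. The true size of the step stays unknown, and only its floor can be stated, which is set by where compound 2 stands: the limit of > 100000 nM in this assay, at which 1 of the 3 values shown sits.

Compound 1, at 3700 nM, differs from compound 3 in two places, so it cannot show how much of the remaining distance belongs to the group on the carbonyl and how much to the other ring. As far as these compounds go, it also remains open how this position would respond to a plain phenyl or a pyridine ring on the carbonyl, or whether the same thiophene swap would matter at the remaining furan of compound 3.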